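Fixing one stereocentre in a difluorobenzyl amide

A few compounds are considered here, and "the series" means these few. Any claim that something is new, unique, unknown or untested is made for them only; others in the source may bear on it.

Values in a functional assay on A-375 cells (Homo sapiens) for activation, with a stated time of 3 days; a higher number here means that more compound is needed for the effect, a lower number that less compound is needed:
- compound 1 `O=C(Nc1ccc(-c2cscn2)cc1)C1CCCN(Cc2ccc(F)c(F)c2)C1`: 1240 nM
- compound 2 `O=C(Nc1ccc(-c2cscn2)cc1)C1CCN(Cc2ccc(F)c(F)c2)C1`: 8000 nM
- compound 3 `O=C(Nc1ccc(-c2cscn2)cc1)C1CCCN(C(=O)c2ccc(F)c(F)c2)C1`: > 20000 nM (a limit of the assay)

Of the two actual numbers in this assay, the lower belongs to compound 1 at 1240 nM, while compound 2 lies clearly higher at 8000 nM. The entry for compound 3 is a limit and not a number: > 20000 nM.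

The next compound is compound 4 `O=C(Nc1ccc(-c2cscn2)cc1)[C@@H]1CCCN(Cc2ccc(F)c(F)c2)C1`, and it differs from compound 1 in one respect only: the two compounds have the same atoms and bonds; at least one stereo element is drawn with a configuration in one of them and without one in the other: 1 of 1 stereo elements differ; a stereocentre at a saturated ring carbon is drawn without a configuration in compound 1 and R in compound 4.

Among the measured compounds shown here, only one measured step is available, an at least 16-fold higher number from compound 1 to compound 3 (1.20 log units; beyond the scatter). That step replaces 3,4-difluorobenzyl with (3,4-difluorophenyl)carbonyl on an amine nitrogen in a ring, and leaves the stereocentre untouched. It therefore bears on the present change only indirectly, showing that this assay can respond strongly to a change in one place. For the measured compounds named here, no measured pair isolates a configuration, so the direction stays uncertain, and a moderate move toward a higher number is expected, with a wide margin on both sides.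

For compound 4 the expected value is 2800 nM, with an estimated range of 600 nM to 18000 nM. The estimate means a 2.3-fold higher number from compound 1 to compound 4 (0.35 log units; beyond the scatter).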

Compound 4, half-maximal effective concentration: 4000 nM
Compound 4: the middle estimate sits 1.4-fold (0.15 log units) below what was measured; the range from low to high includes it.
By their numbers in this assay, from the lowest: compound 1; then compounds 4 and 2 (each within the scatter of the next). At a limit, above all of these: compound 3.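

Drawing the stereocentre at the saturated ring carbon as R gives, in this assay, a 3.2-fold higher number from compound 1 to compound 4 (0.51 log units; beyond the scatter), a modest step but one beyond the usual scatter. Among the compounds shown here, this is the first measured pair in which the atoms and bonds stay the same, so it shows that the read-out can differ at this position even when the 3,4-difluorobenzyl group and the rest of the structure are unchanged. The step does not compare two defined configurations, and its size cannot be taken as the full gap between the R form and its mirror image, because the comparison rests on this: the fact that one of compounds 1 and 4 is drawn with a defined configuration and the other without, at the place where they differ

The compounds shown leave open how the S configuration at this carbon would read in this assay, and so which configuration gives the lower number. They also leave open whether the effect of configuration would persist with an unsubstituted benzyl group or a longer chain, such as phenethyl, on the same ring nitrogen.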